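Second Methoxy on the Pendant Ring: Small Change Expected

The source may hold more compounds than are shown below. What is called first, only, known or untested is meant among the compounds shown, and "the series" means these compounds.

Compound 3 `COc1ccc(CN2C(=O)C(=O)c3cc(-c4cccc(OC)c4)ccc32)cc1` gives 100 nM in a functional assay on K562 cells (Homo sapiens) for antiproliferative activity, read by MTT assay, with a stated time of 48 h (a higher number here means a weaker inhibitor, a lower number a stronger inhibitor), the second highest of the three numbers measured. Compound 1 `COc1ccc(CN2C(=O)C(=O)c3cc(-c4ccc(OC)cc4)ccc32)cc1` gives 30 nM, and compound 2 `COc1ccc(CN2C(=O)C(=O)c3ccc(-c4ccc(OC)cc4)cc32)cc1` gives 7460 nM, so compound 3 lies far from compound 2 and closer to compound 1.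

Compound 4 `COc1ccc(CN2C(=O)C(=O)c3cc(-c4cc(OC)cc(OC)c4)ccc32)cc1` differs from compound 3 by methoxy in place of hydrogen on an aromatic carbon. Within the data shown here, no measured pair shows exactly this addition. Among the measured compounds shown here, the only step on the same pendant ring, a 3.3-fold higher number from compound 1 to compound 3 (0.52 log units; beyond the scatter), moved a single methoxy from one aromatic carbon to another rather than adding a second one, and it was modest. A second methoxy is therefore expected to shift the number only slightly, if at all, leaning toward a higher value; the expected step is a 1.5-fold higher number from compound 3 to compound 4 (0.18 log units; within the scatter). Compound 4 is estimated at 150 nM, within 50 nM to 500 nM.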

Compound 4, half-maximal inhibitory concentration: 510 nM
For compound 4 the middle estimate is 3.4-fold (0.53 log units) below the measured one, outside the stated range (above it).
By their numbers in this assay, from the lowest: compound 1; then compound 3; then compound 4; then compound 2.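

Adding a methoxy to the 3-methoxyphenyl ring is not a neutral change: in this assay it gives a 5.1-fold higher number from compound 3 to compound 4 (0.71 log units; beyond the scatter) and so a weaker inhibitor. Replacing the 4-methoxyphenyl group with 3,5-dimethoxyphenyl gives a 17-fold higher number from compound 1 to compound 4 (1.23 log units; beyond the scatter) and shows how much a single change on this ring can matter. No measurement shown here explains the loss. Still open, going by these compounds, is how a hydroxyl group, a fluorine or an amine would read in this assay if placed on this carbon instead of the added methoxy.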